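Swapping an Aryl Cap for a Pentyl Chain

A few compounds are considered here, and "the series" means these few. Any claim that something is new, unique, unknown or untested is made for them only; others in the source may bear on it.

Compound 1 `Cc1c(-n2cc(COc3ccc(/C=C/C(=O)c4ccc5c(c4O)CCC(C)(C)O5)cc3)nn2)cccc1[N+](=O)[O-]` gives 145000 nM in a functional assay on MCF7 cells (Homo sapiens) for antiproliferative activity, read by MTT assay (a higher number here means a weaker inhibitor, a lower number a stronger inhibitor), a weak result. Compound 2 `CCc1ccccc1-n1cc(COc2ccc(/C=C/C(=O)c3ccc4c(c3O)CCC(C)(C)O4)cc2)nn1`, a close relative, is reported in this assay only as "not active" (no number reported), with no number attached, so it stands at the weak end without a value to compare against. Compound 3 `CCCCCn1cc(COc2ccc(/C=C/C(=O)c3ccc4c(c3O)CCC(C)(C)O4)cc2)nn1` differs from compound 2 by pentyl in place of 2-ethylphenyl on an aromatic nitrogen. Nothing measured here shows how such a change moves this assay, so no step beyond the scatter is assumed in either direction. Compound 3 is therefore expected to remain weak, with an estimated 150000 nM and a likely range from 40000 nM to 600000 nM.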

Compound 3, half-maximal inhibitory concentration: 191000 nM
Estimate against measurement, compound 3: 1.3-fold (0.10 log units) below; the measured number falls inside the stated range.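

In this assay, putting pentyl in place of 2-methyl-3-nitrophenyl on the aromatic nitrogen gives a 1.3-fold higher number from compound 1 to compound 3 (0.12 log units; within the scatter), so at this position a chain with no ring performs on a par with this aryl group, and both compounds remain weak. Compound 2 has no number, so its step to compound 3 cannot be read. Nothing available explains this result.

The compounds shown leave open whether an amine, a carboxylic acid or a chain longer than pentyl on this nitrogen would move the number beyond the scatter.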